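Working notes: from compound 3 to compound 4

A few compounds are considered here, and "the series" means these few. Any claim that something is new, unique, unknown or untested is made for them only; others in the source may bear on it.

In a functional assay on MKN-45 cells (Homo sapiens) for inhibition, read by CCK-8 assay, with a stated time of 24 h (on this read-out higher numbers stand for weaker inhibition and lower numbers for stronger inhibition), compound 3 (`O=C1Nc2ccc(F)cc2/C1=C/c1ccc(-c2cn(-c3ccc(F)cc3)nn2)cc1`) gives > 20000 nM and this is a limit, not a number. Compound 1 (`N#Cc1cccc(-n2cc(-c3ccc(/C=C4\C(=O)Nc5ccccc54)cc3)nn2)c1`), which carries 3-cyanophenyl, gives > 20000 nM and this too is a limit. Going by the values given here, compound 2 (`Cc1cccc(-n2cc(-c3ccc(/C=C4\C(=O)Nc5ccc(F)cc54)cc3)nn2)c1`), with 3-methylphenyl, gives 6810 nM as the only true number so far. Compound 4 (`N#Cc1cccc(-n2cc(-c3ccc(/C=C4\C(=O)Nc5ccc(F)cc54)cc3)nn2)c1`) has 3-cyanophenyl in place of 4-fluorophenyl on an aromatic nitrogen. Among the compounds with values here, the one measured step at this place is an at least 2.9-fold higher number from compound 2 to compound 3 (0.46 log units; beyond the scatter) and it lies beyond the scatter. Two readings sit at the ceiling (the limit of > 20000 nM in this assay, at which 2 of the 3 values shown sit), so the evidence is thin. A modest move toward stronger inhibition is expected, estimated as an at least 1.5-fold lower number from compound 3 to compound 4 (0.18 log units; that floor lies within the scatter) in this assay for now. The estimated value for compound 4 is 13000 nM with an expected range from 5000 nM to 30000 nM in this series.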

Compound 4, half-maximal inhibitory concentration: > 20000 nM
Compound 4 ended at the assay's limit; the forecaster's own chance of this, stated with the estimate: 45%; middle value at least 1.5-fold (0.18 log units) away from the limit.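

In this assay, cyano in place of methyl on an aromatic carbon gives an at least 2.9-fold higher number from compound 2 to compound 4 (0.46 log units; beyond the scatter), so 3-cyanophenyl, like 4-fluorophenyl, falls short of 3-methylphenyl on this aromatic nitrogen. With the fluoro core held constant, the methyl group is now the only substituent shown that gives a value rather than a limit. The steps to compound 4 from compound 3 and from compound 1 cannot be read: the limit of > 20000 nM in this assay, at which 3 of the 4 values shown sit.

From the compounds shown here alone, what an ethyl group, a methoxy group or an amine would give at this place on the phenyl ring remains open. Going by these compounds, whether fluoro on the core matters at all also remains open.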